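A few compounds are considered here, and "the series" means these few. Any claim that something is new, unique, unknown or untested is made for them only; others in the source may bear on it.

Working notes on the series. Compound 1 `COc1cc(Nc2ncccc2-c2n[nH]c(Nc3cc(Cl)cc(Cl)c3)n2)cc(OC)c1` gives "not determined" (no result reported) in a functional assay on A-431 cells (Homo sapiens), tested at 0.1 uM; a lower number here means less inhibition, a higher number more inhibition at the concentration tested (going by the name of the read-out). In this assay compound 2 `COc1cc(Nc2ncccc2-c2n[nH]c(Nc3ccc4c(c3)OCCO4)n2)cc(OC)c1` gives 83%. Compound 3 `COc1cc(OC)cc(Oc2ncccc2-c2n[nH]c(Nc3cccc(O)c3)n2)c1` gives 86% in this assay; compound 3 and compound 2 lie within the usual scatter of each other, so nothing separates them on the numbers at hand, and compound 1 contributes no number. Within the data shown here, no pair of measured compounds differs in a single place, so no measured step is available.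

Compound 4 `COc1cc(OC)cc(Oc2ncccc2-c2n[nH]c(Nc3ccc(C#N)cc3)n2)c1` differs from compound 3 by 4-cyanophenyl in place of 3-hydroxyphenyl on a nitrogen on an aromatic ring. Both measured numbers in this assay are high and close together, which gives no sign of how the change at the nitrogen on the aromatic ring shifts the read-out. The expected step of a number 8 percentage points lower from compound 3 to compound 4 (within the scatter) is small and not beyond the scatter, with a slight lean downward because compound 3 already sits at 86%. The estimate for compound 4 in this assay is 78%, in the range 55% to 92%.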

Compound 4, a percentage reported as inhibition, at one concentration (the size of the read-out at that concentration, not a potency): 27%
Compound 4: the middle estimate sits 51 percentage points above what was measured; the whole stated range lies above it.
By their numbers in this assay, from the lowest: compound 4; then compounds 2 and 3 (each within the scatter of the next).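

Among these compounds, at the nitrogen on an aromatic ring, the identity of the aryl group matters strongly in this assay: 4-cyanophenyl in place of 3-hydroxyphenyl gives a number 59 percentage points lower from compound 3 to compound 4 (beyond the scatter), the first measured step and one beyond the scatter. The step combines two differences, the substituent itself and its numbered place on the phenyl ring, and it also removes the hydrogen-bond donor counted for 3-hydroxyphenyl, so no single one of these can be singled out from this pair. Nothing at hand accounts for the size of the step.

Open, as far as these compounds go, is whether 3-cyanophenyl or 4-hydroxyphenyl on the same nitrogen would read like compound 3 or like compound 4. Also open, from the compounds shown here alone, is whether 3-aminophenyl or 3-methoxyphenyl there would hold the high number of compound 3.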